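A few compounds are considered here, and "the series" means these few. Any claim that something is new, unique, unknown or untested is made for them only; others in the source may bear on it.

Compound 3 `O=C1O[C@H]([C@@H](O)Cn2cc(CNS(=O)(=O)c3ccc(Cl)cc3)nn2)C(OCc2ccccc2)=C1OCc1ccccc1` is one of three measured analogues sharing a core that carries a substituted triazole. In a functional assay on CFPAC-1 cells (Homo sapiens) for antiproliferative activity, read by MTT assay, with a stated time of 72 h (on this read-out lower numbers stand for stronger inhibition and higher numbers for weaker inhibition), compound 3 gives 38900 nM. It stands second highest of the three numbers: its nearest neighbour is compound 2 `COc1ccc(-c2cn(C[C@H](O)[C@H]3OC(=O)C(OCc4ccccc4)=C3OCc3ccccc3)nn2)cc1`, which gives 26000 nM, and the furthest is compound 1 `O=C1O[C@H]([C@@H](O)Cn2cc(-c3cc(F)cc(F)c3)nn2)C(OCc2ccccc2)=C1OCc1ccccc1`, which gives 62400 nM. The step of a 1.6-fold lower number from compound 1 to compound 3 (0.21 log units; within the scatter) and the step of a 1.5-fold higher number from compound 2 to compound 3 (0.17 log units; within the scatter) both stay within the scatter, while the step of a 2.4-fold lower number from compound 1 to compound 2 (0.38 log units; beyond the scatter) is the only one that reaches beyond it.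

Compound 4 `O=C1O[C@H]([C@@H](O)Cn2ccnn2)C(OCc2ccccc2)=C1OCc1ccccc1` differs from compound 3 in a single place: hydrogen in place of (((4-chlorophenyl)sulfonyl)amino)methyl on an aromatic carbon. Going by the values given here, no measured step removes a group from this ring carbon altogether; the steps that bear on it only exchange one group for another, and those exchanges moved the numbers little. On that basis a step of no great size is expected in this assay, with a slightly higher number more likely than a lower one, so the step of a 1.3-fold higher number from compound 3 to compound 4 (0.11 log units; within the scatter) is expected. Compound 4 is estimated at 50000 nM, within a range from 18000 nM to 140000 nM.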

Compound 4, half-maximal inhibitory concentration: > 100000 nM
Compound 4 ended at the assay's limit; the forecaster's own chance of this, stated with the estimate: 20%; at least 2.0-fold (0.30 log units) between middle value and limit.
By their numbers in this assay, from the lowest: compounds 2, 3 and 1 (each within the scatter of the next, the first and the last beyond it). At a limit, above all of these: compound 4.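

In this assay compound 4 reads as a limit of the assay, not as a number: the limit of > 100000 nM in this assay, at which 1 of the 4 values shown sits. Where the earlier compounds only exchanged one group for another with little movement, hydrogen on this aromatic carbon gives a clear loss against two of them: an at least 2.5-fold higher number from compound 3 to compound 4 (0.41 log units; beyond the scatter), and an at least 3.8-fold higher number from compound 2 to compound 4 (0.58 log units; beyond the scatter), so both (((4-chlorophenyl)sulfonyl)amino)methyl and 4-methoxyphenyl go with a measurable number that the bare ring lacks. Compound 1 does not clearly follow this pattern: an at least 1.6-fold higher number from compound 1 to compound 4 (0.20 log units; that floor lies within the scatter), so the data do not show 3,5-difluorophenyl to count in the same way.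

Going by these compounds, whether a methyl, an aminomethyl or a carboxylic acid on this ring carbon would already restore a measurable number remains open. So does the true value of compound 4 beyond its limit.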